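Replacing Benzofuranyl with Methylphenyl in a Receptor Agonist Series

A few compounds are considered here, and "the series" means these few. Any claim that something is new, unique, unknown or untested is made for them only; others in the source may bear on it.

Among the compounds with values here, compound 2 `Cc1nc(-c2cc3ccccc3o2)sc1COc1ccc2c(c1)OCC2CC(=O)O` gives 14.8% in a functional assay on CHO cells for agonist activity at Free fatty acid receptor 1 (Homo sapiens), read by FLIPR and calcium flux, tested at 100 nM (on this read-out lower numbers stand for a weaker effect and higher numbers for a stronger effect at the one concentration tested), the lowest of the two numbers known so far; compound 1 `Cc1nc(-c2ccccc2)sc1COc1ccc2c(c1)OCC2CC(=O)O` gives 54.8%. Compound 3 `Cc1ccccc1-c1nc(C)c(COc2ccc3c(c2)OCC3CC(=O)O)s1` carries 2-methylphenyl in place of 1-benzofuran-2-yl on an aromatic carbon. Within the data shown here, the only measured step that bears on this change is a number 40 percentage points lower from compound 1 to compound 2 (beyond the scatter), and the new compound partly reverses it by returning to one six-membered aromatic ring of carbon only. A rise well beyond the scatter is therefore expected, though not necessarily a full return. The expected step is a number 27.2 percentage points higher from compound 2 to compound 3 (beyond the scatter). Compound 3 is expected to reach 42%, within a range from 18% to 65%.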

Compound 3, a percentage reported as activity, at one concentration (the size of the read-out at that concentration, not a potency): 10.7%
Beside the measured number, compound 3's estimate is 31.3 percentage points above it; the whole stated range lies above it.
By their numbers in this assay, from the lowest: compounds 3 and 2 (each within the scatter of the next); then compound 1.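

In this assay, 2-methylphenyl in place of 1-benzofuran-2-yl brings no recovery, with a number 4.1 percentage points lower from compound 2 to compound 3 (within the scatter), so one six-membered aromatic ring of carbon only does not by itself restore the read-out at this position. A single methyl group separates the two phenyl-bearing compounds, and that change comes with a number 44.1 percentage points lower from compound 1 to compound 3 (beyond the scatter). No measurement at hand accounts for this result. Still open, from the compounds shown here alone, is how a fluorine atom or a methoxy group would compare with that methyl group at the same place on the phenyl ring.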